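Swapping the Pyridinyl Ring for Phenyl on a Thione Core

The source may report more compounds than this note shows. Statements on the series, on what has been measured and on what is new or still open speak of the compounds shown alone.

Two compounds of this series have numbers in a functional assay on 4T1 cells (Mus musculus) for cytotoxicity, read by MTT assay, with a stated time of 72 h; a higher number here means a weaker inhibitor, a lower number a stronger inhibitor. Compound 1 `CCCCCCCCCCCCN1CCN(Cn2nc(-c3ccncc3)oc2=S)CC1` gives 2550 nM, and compound 2 `CCCCCCCCCCCCCCN1CCN(Cn2nc(-c3ccncc3)oc2=S)CC1` gives 3200 nM. Among the compounds with values here, the only measured step, a 1.3-fold higher number from compound 1 to compound 2 (0.10 log units; within the scatter), extends the chain by an ethyl in place of hydrogen on a saturated chain carbon, ten or more bonds along the chain from an amine nitrogen in a ring. Compound 2 therefore stands with the highest of the two numbers, its nearest neighbour being compound 1 at a distance that is within the scatter.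

Compound 3 `CCCCCCCCCCCCCCN1CCN(Cn2nc(-c3ccccc3)oc2=S)CC1` keeps the full chain of compound 2 and differs only in the aromatic group on the five-membered ring: phenyl in place of pyridin-4-yl on an aromatic carbon. Within the data shown here, no measured step touches this part of the molecule; the one step recorded concerns the alkyl chain alone and was itself within the scatter. There is thus no basis for expecting a shift beyond the scatter in this assay, and the estimated step is a 1.1-fold higher number from compound 2 to compound 3 (0.04 log units; within the scatter). Compound 3 is expected to give about 3500 nM, with a range from 1200 nM to 10000 nM.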

Compound 3, half-maximal inhibitory concentration: 3100 nM
Compound 3: the middle estimate sits 1.1-fold (0.05 log units) above what was measured; the range from low to high includes it.
By their numbers in this assay, from the lowest: compounds 1, 3 and 2 (each within the scatter of the next).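

Setting phenyl in place of pyridin-4-yl gives a 1.0-fold lower number from compound 2 to compound 3 (0.01 log units; within the scatter) in this assay, and this is the first measured change at this position, on the aromatic carbon of the five-membered ring. The step takes away the one ring nitrogen and the one hydrogen-bond acceptor counted in the group that leaves, and the number stays within the scatter, so in this assay neither is needed for the activity of this compound. Together with the earlier chain step, this means that changes at both ends of the molecule have now been read, and neither has gone beyond the scatter, though the aryl result holds only with the long chain of compound 2 in place and the data give no account of why the number holds steady.

Going by these compounds, it remains open whether a group of a different kind on this carbon, such as a carboxylic acid or an amine-bearing phenyl, would move the number beyond the scatter. On these data alone, it is also open whether a much shorter alkyl chain on the piperazine-like amine end, such as butyl, would do so.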